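Cyclising the carbamate on the shared core: expected outcome

The source may report more compounds than this note shows. Statements on the series, on what has been measured and on what is new or still open speak of the compounds shown alone.

Measured so far:
compound 1, `COC(=O)Nc1c(N)nc(-c2nn(Cc3ccccc3F)c3ncccc23)nc1N`, 0.3 uM
compound 2, `Nc1nc(-c2nn(Cc3ccccc3F)c3ncccc23)nc(N)c1NC(=O)OCC(F)(F)F`, 0.2 uM

Both values come from an assay on cells for activation of Guanylate cyclase soluble subunit alpha-1 (Rattus norvegicus), read by cGMP accumulation and immunoassay, with a stated time of 10 min; a lower number here means that less compound is needed, a higher number that more compound is needed for the effect. Among the measured compounds shown here, compound 2 gives the lowest of the two numbers in this assay, but its only neighbour is compound 1, and the step of a 1.5-fold lower number from compound 1 to compound 2 (0.18 log units; within the scatter) lies within the scatter, so the two cannot be ordered.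

Compound 3, `Nc1nc(-c2nn(Cc3ccccc3F)c3ncccc23)nc(N)c1N1CCOC1=O`, is not yet measured. It differs from compound 2 as follows: 2-oxo-1,3-oxazolidin-3-yl in place of ((2,2,2-trifluoroethoxy)carbonyl)amino on an aromatic carbon. For the measured compounds named here, the only measured step, a 1.5-fold lower number from compound 1 to compound 2 (0.18 log units; within the scatter), changes the chain on the oxygen and not the amide hydrogen, so it bears on this change only loosely. Going by the values given here, with no step in this assay that removes a hydrogen-bond donor or closes a ring, a move beyond the scatter in either direction cannot be ruled out. On balance compound 3 is expected at 0.5 uM, within 0.1 uM to 3 uM, which means an expected step of a 2.5-fold higher number from compound 2 to compound 3 (0.40 log units; beyond the scatter).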

Compound 3, minimum effective concentration: 0.3 uM
Compound 3: middle estimate off by 1.7-fold (0.22 log units), on the high side; measured number inside the range.
By their numbers in this assay, from the lowest: compounds 2, 1 and 3 (each within the scatter of the next).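

Replacing the open carbamate with 2-oxo-1,3-oxazolidin-3-yl removes the amide hydrogen and closes a ring, and in this assay this gives a 1.5-fold higher number from compound 2 to compound 3 (0.18 log units; within the scatter) and, against (methoxycarbonyl)amino, no change at the digits printed from compound 1 to compound 3 (within the scatter). The amide hydrogen is therefore not required for a reading in this range at this position, on the aromatic carbon ortho to two amino groups, and ring closure is tolerated as well. No measurement bears on why the reading holds across this change.

As far as these compounds go, whether the carbamate oxygen or carbonyl matters remains open, as all three compounds keep both, and a urea, an acetamide or a plain amine at this position would test this. An N-methyl carbamate would separate the loss of the amide hydrogen from the closing of the ring.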